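Plasma half-life: methoxy in place of aziridine on carbonyl

This account rests on a few compounds, and the source may have more. Where it says the series, first, only, none or still open, it means among the compounds named here.

Of the compounds shown here, two have been measured. Compound 1 `Cc1cc(/C=C/C#N)cc(C)c1Oc1cc(Nc2ccc(C#N)cc2)c(N)cc1C(=O)NN` and compound 2 `Cc1cc(/C=C/C#N)cc(C)c1Oc1cc(Nc2ccc(C#N)cc2)c(N)cc1C(=O)N1CC1` share the same core and differ only in the group on the carbonyl carbon. In an ADME assay on a cell-free system (plasma, Homo sapiens) for metabolic stability, read by LC-MS, tested at 10 ug/mL (on this read-out lower numbers stand for a shorter-lived compound and higher numbers for a longer-lived compound), compound 1 gives 8 h, and in the same assay compound 2 gives 12 h. The step of a 1.5-fold higher number from compound 1 to compound 2 (0.18 log units; within the scatter) is the only one available, and it does not separate the two compounds. Compound 2 therefore holds the higher of the two numbers, but the gap to compound 1 falls within the scatter and no order can be read from it.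

Compound 3 `COC(=O)c1cc(N)c(Nc2ccc(C#N)cc2)cc1Oc1c(C)cc(/C=C/C#N)cc1C` has not yet been tested in this assay. Its change from compound 2 is methoxy in place of aziridin-1-yl on a carbonyl carbon. Among the compounds with values here, the one measured step that bears on it, the exchange of the group on the same carbonyl carbon from compound 1 to compound 2, left the half-life within the scatter. On that basis compound 3 is expected to differ from compound 2 by about a 1.3-fold lower number from compound 2 to compound 3 (0.12 log units; within the scatter), which is no step beyond the scatter. The estimate for compound 3 in this assay is 9 h, with a range of 3 h to 20 h.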

Compound 3, half-life: 89 h
The estimate for compound 3 lay 9.9-fold (1.00 log units) below the measured number, outside the stated range (above it).
By their numbers in this assay, from the lowest: compounds 1 and 2 (each within the scatter of the next); then compound 3.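

In this assay, the group on the carbonyl carbon proves able to move the number a long way: methoxy in place of aziridin-1-yl gives a 7.4-fold higher number from compound 2 to compound 3 (0.87 log units; beyond the scatter), and methoxy in place of aminoamino gives an 11-fold higher number from compound 1 to compound 3 (1.05 log units; beyond the scatter). The earlier exchange at this place, between aminoamino and aziridin-1-yl, had stayed within the scatter, so that step gave no sign that this position was sensitive. Among these three compounds, the two groups attached to the carbonyl carbon through nitrogen sit together and methoxy, attached through oxygen, stands apart, with no compound going against this split; no data at hand explain the gap.

The compounds shown leave open whether the higher number belongs to methoxy alone or extends to other groups attached through oxygen, such as ethoxy or a longer alkoxy chain, and how a free carboxylic acid at this place would read. They also leave open whether a simple dimethylamino group on the same carbonyl carbon would sit with aminoamino and aziridin-1-yl, which would test the split between nitrogen and oxygen attachment.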